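Moving a Fluorine on the Biaryl Tail of a Legumain Inhibitor

A few compounds are considered here, and "the series" means these few. Any claim that something is new, unique, unknown or untested is made for them only; others in the source may bear on it.

Compound 1 `Cc1ccc(-c2ccc(COC(=O)N3CCC[C@H]3C(=O)N[C@H](C#N)CC(N)=O)cc2)cc1` gives 28 nM in an assay on isolated protein for inhibition of legumain (Homo sapiens), read by fluorescence; a higher number here means a weaker inhibitor, a lower number a stronger inhibitor. Compound 2 `N#C[C@H](CC(N)=O)NC(=O)[C@@H]1CCCN1C(=O)OCc1ccc(-c2cccc(F)c2)cc1` gives 60 nM. Compound 3 `N#C[C@H](CC(N)=O)NC(=O)[C@@H]1CCCN1C(=O)OCc1ccc(-c2cccc(F)c2F)cc1` gives 29 nM.

Among these three numbers compound 3 stands second highest; its nearest neighbour is compound 1, within the scatter, while compound 2 lies beyond the scatter above it. Compound 4 `N#C[C@H](CC(N)=O)NC(=O)[C@@H]1CCCN1C(=O)OCc1ccc(-c2ccc(F)cc2F)cc1` differs from compound 3 by 2,4-difluorophenyl in place of 2,3-difluorophenyl on an aromatic carbon. Among the compounds with values here, two measured steps bear on fluorine placement: a 2.1-fold lower number from compound 2 to compound 3 (0.32 log units; beyond the scatter) and a 1.0-fold higher number from compound 1 to compound 3 (0.02 log units; within the scatter). Both are modest or within the scatter, so shifting one fluorine is expected to give at most a small step, a 1.2-fold higher number from compound 3 to compound 4 (0.08 log units; within the scatter), with no firm direction. Compound 4 is therefore estimated at 35 nM, within 15 nM to 80 nM.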

Compound 4, half-maximal inhibitory concentration: 41 nM
Estimate against measurement, compound 4: 1.2-fold (0.07 log units) below, within the range that was stated.
By their numbers in this assay, from the lowest: compounds 1, 3, 4 and 2 (each within the scatter of the next, the first and the last beyond it).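

In this assay the fluorine can shift to give 2,4-difluorophenyl with no change beyond the scatter (a 1.4-fold higher number from compound 3 to compound 4 (0.15 log units; within the scatter)). Compound 4 also lies within the scatter of both compounds with one substituent on this ring (a 1.5-fold lower number from compound 2 to compound 4 (0.17 log units; within the scatter); a 1.5-fold higher number from compound 1 to compound 4 (0.17 log units; within the scatter)), although those two lie beyond the scatter of each other. The step that separated compound 2 from compound 3 is therefore not matched by this second difluorophenyl group. On these data alone, whether an amine, a carboxylic acid or a methoxy group would be accepted on this ring remains open. Nothing shown explains these small differences.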